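Series notes: the step from compound 3 to compound 4

The compounds below may be only part of what the source reports. "The series", "measured", "known", "first", "only" and "open" are said of these compounds alone.

The shared core is set by compound 1 `CC(C)n1ncc2c(C(=O)Nc3ccccc3)cccc21`; in a functional assay on PC-3 cells (Homo sapiens) for inhibition, read by MTT assay, with a stated time of 72 h (a higher number here means a weaker inhibitor, a lower number a stronger inhibitor), compound 1 gives 11900 nM. Compound 2 `CC(C)n1ncc2c(C(=O)NCc3ccccc3)cccc21` gives 15200 nM in this assay. For the measured compounds named here, the one step measured within the set, a 1.3-fold higher number from compound 1 to compound 2 (0.11 log units; within the scatter), puts benzyl in place of phenyl on an amide-type nitrogen and leaves the number where it was. Compound 3 `CC(C)n1ncc2c(C(=O)NCc3cn(-c4ccc([N+](=O)[O-])cc4)nn3)cccc21` is only bounded: in this assay compound 3 gives > 40000 nM, which is a limit of the assay and not a number. Where compound 3 stands is therefore told only by the limit of > 40000 nM in this assay, at which 1 of the 3 values shown sits.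

Compound 4 `CC(C)n1ncc2c(C(=O)NCc3cn(Cc4ccc(C#N)cc4)nn3)cccc21` differs from compound 3 in a single place, (4-cyanobenzyl in place of 4-nitrophenyl on an aromatic nitrogen). Going by the values given here, no measured step covers a change of this kind on an aromatic nitrogen of a five-membered aromatic ring with 3 nitrogen, and the step already noted on the amide-type nitrogen was within the scatter. Nothing in the measured set points to a move out of the weak range.

Compound 4 is expected at 40000 nM, with a range from 15000 nM to 100000 nM. The expected step of a number no higher from compound 3 to compound 4 (the limit leaves the size open) means no change beyond the scatter. Compound 4 is thus expected to return a limit rather than a number in most repeats.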

Compound 4, half-maximal inhibitory concentration: 18200 nM
For compound 4 the middle estimate is 2.2-fold (0.34 log units) above the measured one; measured number inside the range.
By their numbers in this assay, from the lowest: compounds 1, 2 and 4 (each within the scatter of the next). At a limit, above all of these: compound 3.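

On the aromatic nitrogen of the five-membered aromatic ring with 3 nitrogen, 4-cyanobenzyl in place of 4-nitrophenyl gives an at least 2.1-fold lower number from compound 3 to compound 4 (0.34 log units; beyond the scatter) in this assay, whereas the earlier step on the amide-type nitrogen stayed within the scatter. This position therefore responds to change, and a substituted five-membered aromatic ring on the amide side chain can return a number rather than a limit: compound 4 gives 18200 nM. The step exchanges the nitro group for a nitrile and the phenyl for a benzyl together, so the compounds shown cannot assign it to either part.

As far as these compounds go, the full size of the step stays open because compound 3 stands at a limit, which is not a number: the limit of > 40000 nM in this assay, at which 1 of the 4 values shown sits. Also open is how 4-cyanophenyl or 4-nitrobenzyl on the same aromatic nitrogen would read, which would separate the two parts of the change, and how an amine, a carboxylic acid or a longer chain in place of the 4-cyanobenzyl would read in this assay.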